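Shortening a Pentyl Chain on the Piperazine Nitrogen

A few compounds are considered here, and "the series" means these few. Any claim that something is new, unique, unknown or untested is made for them only; others in the source may bear on it.

Measured so far:
Compound 1, `CN1CCN(c2nc3ccccc3n2CCO)CC1`: 410 nM
Compound 2, `CCCCCN1CCN(c2nc3ccccc3n2CCOCC)CC1`: 30 nM

In a functional assay on ileum for inhibition of histamine H1 receptor (Cavia porcellus) (on this read-out higher numbers stand for weaker inhibition and lower numbers for stronger inhibition), compound 1 gives 410 nM, while compound 2 gives 30 nM. Of the two numbers, compound 2 stands lowest, and its gap to compound 1 lies beyond the scatter of repeated measurements. Compound 3, `CCCCN1CCN(c2nc3ccccc3n2CCOCC)CC1`, has not yet been measured. It differs from compound 2 in one place: hydrogen in place of methyl on a saturated chain carbon, four bonds along the chain from an amine nitrogen in a ring. Such a small trimming of a chain by a single carbon usually shifts this read-out only modestly, if at all. The step from compound 2 to compound 3 is therefore expected to be small, most likely within the scatter or at most slightly weakening, as a 1.5-fold higher number from compound 2 to compound 3 (0.18 log units; within the scatter). Compound 3 is accordingly expected to give about 45 nM, within a range from 15 nM to 130 nM.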

Compound 3, half-maximal inhibitory concentration: 15 nM
The estimate for compound 3 lay 3.0-fold (0.48 log units) above the measured number; the range from low to high includes it.
By their numbers in this assay, from the lowest: compounds 3 and 2 (each within the scatter of the next); then compound 1.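

Going by these compounds alone, this is the first pair here that differs in only one place, so a single change to the chain on the ring's amine nitrogen can be judged on its own. In this assay, hydrogen in place of methyl on a saturated chain carbon, four bonds along the chain from an amine nitrogen in a ring, gives a 2.0-fold lower number from compound 2 to compound 3 (0.30 log units; within the scatter) so the two compounds cannot be told apart and losing this one carbon leaves no clear mark on the read-out. No measurement available here explains this result.

Going by these compounds, whether a propyl or ethyl chain, a longer hexyl chain, or a benzyl group at this nitrogen would also leave the read-out unchanged remains open. On these data alone, the chain's contribution relative to compound 1 also remains open, since that compound differs from the others in more than one place.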